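The source may report more compounds than this note shows. Statements on the series, on what has been measured and on what is new or still open speak of the compounds shown alone.

Working notes on the series.

Compound 3 `COc1cc(OC)cc(C(=CC#N)c2ccc(OC)c(N)c2)c1` is the reference here. In a functional assay on HCT-116 cells (Homo sapiens) for cytotoxicity, read by scintillation counting and thymidine incorporation, with a stated time of 72 h (on this read-out lower numbers stand for stronger inhibition and higher numbers for weaker inhibition), compound 3 gives 1.4 nM, the lowest of the two numbers in hand. Compound 1 `COc1cc(OC)cc(C(=CC#N)c2ccc(OC)c(NC(C)=O)c2)c1` differs in carrying an acetyl on the ring nitrogen, and in this assay compound 1 gives 92 nM. Within the data shown here, the step from the acetyl to the free amino, a 66-fold lower number from compound 1 to compound 3 (1.82 log units; beyond the scatter), is the only single change measured so far. Compound 2 `COc1cc(OC)cc(C(=CC(N)=O)c2ccc(OC)c(OC)c2)c1` has the amide and the dimethoxy pattern, and in this assay compound 2 reaches only a limit, > 10000 nM; this rests on the limit of > 10000 nM in this assay, at which 1 of the 3 values shown sits, and gives no number to compare.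

Compound 4 `COc1cc(OC)cc(C(=CC#N)c2ccc(OC)c(OC)c2)c1` is the next target. methoxy in place of amino on an aromatic carbon The change removes the amino that, on the evidence of compound 1 and compound 3, matters for a low number; compound 2 offers no numeric guide. The expectation is therefore a higher number in this assay, a step of a 29-fold higher number from compound 3 to compound 4 (1.46 log units; beyond the scatter) of a size comparable to the acetyl case. Compound 4 is estimated at 40 nM, within 6 nM to 300 nM.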

Compound 4, half-maximal inhibitory concentration: 18 nM
Compound 4: middle estimate off by 2.2-fold (0.35 log units), on the high side; measured number inside the range.
By their numbers in this assay, from the lowest: compound 3; then compound 4; then compound 1. At a limit, above all of these: compound 2.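

In this assay, the free amino gives the lowest number of the groups at this position, but it is not needed for a number in the low range: methoxy in its place gives a 13-fold higher number from compound 3 to compound 4 (1.11 log units; beyond the scatter). Methoxy also compares well with acetamido at the same position, giving a 5.1-fold lower number from compound 1 to compound 4 (0.71 log units; beyond the scatter), so the order here runs amino, methoxy, acetamido. On the chain, cyano in place of carbamoyl gives an at least 550-fold lower number from compound 2 to compound 4 (2.74 log units; beyond the scatter), a step whose starting point is a limit and not a number: the limit of > 10000 nM in this assay, at which 1 of the 4 values shown sits.

Going by these compounds, it remains open where a hydroxyl or a dimethylamino group would fall in this order at the same position. On these data alone, it is also open whether a carboxylic acid or a methyl ester in place of the cyano on the chain would keep the number low.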